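The compounds below may be only part of what the source reports. "The series", "measured", "known", "first", "only" and "open" are said of these compounds alone.

Among the compounds with values here, the two compounds measured so far share a core and differ only in the aryl groups on either side of it. Compound 1 `COc1ccc(S(=O)(=O)c2cnc3c(F)cccc3c2-c2cccc(OC)c2)cc1` carries a 4-methoxyphenyl on the sulfonyl sulfur, and in an ADME assay on microsomes from liver (Homo sapiens) for metabolic stability, tested at 2.5 uM (a higher number here means faster removal of the compound, a lower number slower removal), compound 1 gives 2.87 mL/min. Compound 2 `Cc1ccc(S(=O)(=O)c2cnc3c(F)cccc3c2-c2cccc(Cl)c2)cc1F` carries a 3-fluoro-4-methylphenyl on that sulfur and a 3-chlorophenyl on the core, and in this assay compound 2 gives 3.18 mL/min. Compound 2 has the higher of the two numbers, but its gap to compound 1 lies within the scatter, so the two values cannot be told apart.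

Compound 3 `COc1ccc(S(=O)(=O)c2cnc3c(F)cccc3c2-c2cccc(Cl)c2)cc1` keeps the 3-chlorophenyl of compound 2 and changes only the group on the sulfonyl sulfur, (4-methoxyphenyl in place of 3-fluoro-4-methylphenyl on a sulfonyl sulfur). The same group on the sulfonyl sulfur is already present in compound 1, whose value sits within the scatter of compound 2. Compound 3 is therefore expected to behave like both measured compounds, with a step of a 1.1-fold lower number from compound 2 to compound 3 (0.03 log units; within the scatter) that is estimated to stay within the scatter and in no clear direction. The estimate for compound 3 in this assay is 3 mL/min, with a range from 1.6 mL/min to 5.6 mL/min.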

Compound 3, intrinsic clearance in a liver preparation (reported as CLH), per the amount of preparation that the assay uses: 2.75 mL/min
For compound 3 the middle estimate is 1.1-fold (0.04 log units) above the measured one, within the range that was stated.
By their numbers in this assay, from the lowest: compounds 3, 1 and 2 (each within the scatter of the next).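

With the 3-chlorophenyl held fixed, 4-methoxyphenyl in place of 3-fluoro-4-methylphenyl on the sulfonyl sulfur gives a 1.2-fold lower number from compound 2 to compound 3 (0.06 log units; within the scatter) in this assay, so this exchange alone leaves the two compounds indistinguishable. With the 4-methoxyphenyl held on that sulfur, chloro in place of methoxy on an aromatic carbon gives a 1.0-fold lower number from compound 1 to compound 3 (0.02 log units; within the scatter), which likewise cannot be told from no change; compounds 1 and 2 differ in both places at once, so only compound 3 allows each change to be read separately. No measurement among these data bears on why either change leaves the values so close.

All three compounds lie within the scatter of one another, so the compounds shown do not reveal whether any group on the sulfonyl sulfur can shift the clearance in this assay. As far as these compounds go, it remains open whether an aryl group bearing an amine or a carboxylic acid there, or a longer alkyl chain in place of the aryl group, would give a value beyond the scatter.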